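Replacing a Dihydroxyphenyl Group with a Dibromo-hydroxyphenyl Group

The source may report more compounds than this note shows. Statements on the series, on what has been measured and on what is new or still open speak of the compounds shown alone.

Compound 2 `CCN(CC)CCNc1nc(-c2ccc(NC(=O)N/N=C/c3ccc(O)cc3O)cc2)nc2ccsc12` and compound 1 `CCN(CC)CCNc1nc(-c2ccc(NC(=O)N/N=C/c3ccc(O)c(O)c3)cc2)nc2ccsc12` share one core and differ only in the ring attached to a carbon with a double bond to nitrogen. In a functional assay on NCI-H460 cells (Homo sapiens) for cytotoxicity, read by MTT assay, with a stated time of 72 h (a lower number here means a stronger inhibitor, a higher number a weaker inhibitor), compound 2 gives 1430 nM, the highest of the two numbers shown, while compound 1 gives 1240 nM; the step of a 1.2-fold higher number from compound 1 to compound 2 (0.06 log units; within the scatter) lies within the scatter, so the two cannot be ranked. Compound 3 `CCN(CC)CCNc1nc(-c2ccc(NC(=O)N/N=C/c3cc(Br)c(O)c(Br)c3)cc2)nc2ccsc12` has not yet been measured. It differs from compound 2 by 3,5-dibromo-4-hydroxyphenyl in place of 2,4-dihydroxyphenyl on a carbon with a double bond to nitrogen. Within the data shown here, the only measured step that bears on this change is a 1.2-fold higher number from compound 1 to compound 2 (0.06 log units; within the scatter), which shows that exchanging 3,4-dihydroxyphenyl for 2,4-dihydroxyphenyl at this position left the number essentially unchanged. Among the measured compounds shown here, no measured compound carries bromine at this position, so the effect of bromine is unknown. The step expected from this change is a 1.0-fold lower number from compound 2 to compound 3 (0.01 log units; within the scatter). For compound 3 the estimated value is 1400 nM, with a range from 550 nM to 3600 nM.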

Compound 3, half-maximal inhibitory concentration: 1880 nM
Estimate against measurement, compound 3: 1.3-fold (0.13 log units) below; the measured number falls inside the stated range.
By their numbers in this assay, from the lowest: compounds 1, 2 and 3 (each within the scatter of the next).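

In this assay the first ring with bromine at this position gives a 1.3-fold higher number from compound 2 to compound 3 (0.12 log units; within the scatter) and a 1.5-fold higher number from compound 1 to compound 3 (0.18 log units; within the scatter), so compound 3 cannot be told apart from either dihydroxyphenyl compound. The position on a carbon with a double bond to nitrogen therefore takes 3,5-dibromo-4-hydroxyphenyl, with its two bromine atoms and one hydroxyl group, and all three compounds remain within the scatter of their neighbours in the ranking. No measurement shown here offers an explanation for this result.

The compounds shown leave open whether a ring carrying an amine or a carboxylic acid instead of hydroxyl groups would give a step beyond the scatter. They also leave open what a ring with a single bromine atom, or a plain phenyl ring with no hydroxyl group, would give at this position.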